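This account rests on a few compounds, and the source may have more. Where it says the series, first, only, none or still open, it means among the compounds named here.

Working notes on the series, read in an ADME assay on HT-29 cells (Homo sapiens) for cytotoxicity, read by MTT assay, with a stated time of 72 h; on this read-out lower numbers stand for stronger inhibition and higher numbers for weaker inhibition. Compound 1 `COc1ccc(C2=C(c3cc(OC)c(OC)c(OC)c3)C(=O)C(OC(C)=O)C2)cc1OC(C)C` gives > 100 ug/mL, a limit of the assay. Compound 2 `COC(=O)c1cc(C2=C(c3cc(OC)c(OC)c(OC)c3)C(=O)CC2O[SiH2]C(C)(C)C)ccc1OC` gives > 100 ug/mL, also a limit. Compound 3 `COc1ccc(C2=C(c3cc(OC)c(OC)c(OC)c3)C(=O)CC2O)cc1O` gives < 1 ug/mL, again a limit. Compound 2 therefore stands at the limit of > 100 ug/mL in this assay, at which 2 of the 3 values shown sit, without a number of its own.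

Compound 4 `COCOc1cc(C2=C(c3cc(OC)c(OC)c(OC)c3)C(=O)CC2O[SiH2]C(C)(C)C)ccc1OC` carries methoxymethoxy in place of methoxycarbonyl on an aromatic carbon, (methoxymethoxy in place of methoxycarbonyl on an aromatic carbon). Within the data shown here, no measured step shows this change, so the expectation rests on compound 2 with its > 100 ug/mL. No change beyond the scatter is expected in this assay, in either direction, and the estimated step is a number no higher from compound 2 to compound 4 (the limit leaves the size open). Compound 4 is estimated at 100 ug/mL, with an expected range from 30 ug/mL to 300 ug/mL.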

Compound 4, half-maximal inhibitory concentration: 43 ug/mL
The estimate for compound 4 lay 2.3-fold (0.37 log units) above the measured number; the range from low to high includes it.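

In this assay, methoxymethoxy in place of methoxycarbonyl on this aromatic carbon, ortho to a methoxy group, gives an at least 2.3-fold lower number from compound 2 to compound 4 (0.36 log units; beyond the scatter). Compound 4 gives 43 ug/mL, the only reading shown that is a number and not a limit of the assay. Compound 2 stands at a limit, not a number: the limit of > 100 ug/mL in this assay, at which 2 of the 4 values shown sit.

The full size of the step and its cause stay open. Also open, from the compounds shown here alone, is how an amine or a carboxylic acid on this aromatic carbon would read, with the rest of compound 4 unchanged.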